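The compounds below may be only part of what the source reports. "The series", "measured", "known", "first", "only" and "open" are said of these compounds alone.

Measured compounds and their values in an ADME assay (liver) for metabolic stability, with Liver microsome (Rattus norvegicus) as the target, read by LC-MS, using microsomes and NADPH, with stated times of 5 min and 60 min, tested at 4 uM; on this read-out higher numbers stand for a more stable compound and lower numbers for a less stable compound:

Compound 1, `Cc1c(OCCCCOc2ccc(C(=O)CC(C)(C)C)c(O)c2C)cccc1C(=O)O`, gives 51%.
Compound 2, `CCC(=O)c1ccc(OCCCCOc2ccc(F)c(C(=O)O)c2)c(C)c1O`, gives 35%.
Compound 3, `Cc1c(OCCCCOCOc2ccc(C(=O)O)cc2)ccc(C(=O)CC2CCCC2)c1O`, gives 31%.

Among the three numbers, compound 3 stands lowest in this assay. Its nearest neighbour is compound 2, whose value lies within the scatter of compound 3, so no order between those two can be stated. Compound 1 lies furthest away, beyond the scatter, with the higher value.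

The step to the unmeasured compound 4, `Cc1ccc(C(=O)O)cc1OCCCCOc1ccc(C(=O)CC2CCCC2)c(O)c1C`, is a change at one place on the chain linking the two aromatic parts: 5-carboxy-2-methylphenyl in place of (4-carboxyphenoxy)methyl on an oxygen on a saturated carbon.

For the measured compounds named here, no step between two measured compounds is available as a guide for this change, so the expectation rests on the values shown. Compound 1, which also carries a methyl-bearing carboxyphenyl directly on the chain oxygen, gives 51%, a number above that of compound 3. On that basis compound 4 is expected to show a moderate rise in this assay, a step of a number 14 percentage points higher from compound 3 to compound 4 (beyond the scatter). The estimate for compound 4 is 45%, with a range from 28% to 62%.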

Compound 4, percent of the compound remaining: 9%
Beside the measured number, compound 4's estimate is 36 percentage points above it; the measured number lies below the stated range.
By their numbers in this assay, from the lowest: compound 4; then compounds 3 and 2 (each within the scatter of the next); then compound 1.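

In this assay, putting 5-carboxy-2-methylphenyl in place of (4-carboxyphenoxy)methyl on an oxygen on a saturated carbon gives a number 22 percentage points lower from compound 3 to compound 4 (beyond the scatter). For the compounds shown here, this is the first reading of this place with the rest of the structure held fixed, and it shows that the group carried on the chain oxygen matters in this read-out, since the step lies beyond the usual scatter. Nothing in the data at hand explains this step.

As far as these compounds go, the change alters several features at once, including the methyl group, the place of the carboxylic acid on the ring and the number of oxygens in the group, so the share of each stays open. Also open, from the compounds shown here alone, is how an amide or a tetrazole in place of the carboxylic acid, or a shorter chain, would read in this assay.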